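The source may report more compounds than this note shows. Statements on the series, on what has been measured and on what is new or still open speak of the compounds shown alone.

In an ADME assay on Vero cells (Chlorocebus sabaeus) for cytotoxicity, read by colorimetric assay (on this read-out higher numbers stand for weaker inhibition and lower numbers for stronger inhibition), compound 1 `CCCCCCCc1cc(O)cc(OC(=O)c2c(CCCCCCC)cc(O)cc2O[C@@H]2O[C@H](CO)[C@H](O)[C@H](O)[C@H]2O)c1` gives 43200 nM, the higher of the two numbers shown, though its only neighbour lies within the scatter: compound 2 `CCCCCCCc1cc(O)cc(OC(=O)c2c(CCCCCCC)cc(O)cc2O[C@@H]2O[C@H](CO[C@@H]3O[C@H](CO)[C@H](O)[C@H](O)[C@H]3O)[C@H](O)[C@H](O)[C@H]2O)c1` gives 32100 nM. The step of a 1.3-fold lower number from compound 1 to compound 2 (0.13 log units; within the scatter) puts a 3,4,5-trihydroxy-6-(hydroxymethyl)oxan-2-yl in place of hydrogen on an oxygen on a saturated carbon. Compound 3 `CCCCCCCc1cc(O)cc(OC(=O)c2c(O)cc(O)cc2CCCCCCC)c1` differs from compound 1 in the opposite sense: hydrogen in place of 3,4,5-trihydroxy-6-(hydroxymethyl)oxan-2-yl on an oxygen on an aromatic ring. Within the data shown here, the one measured step bears on it only loosely, touching the same kind of group at a different oxygen, and stayed within the scatter. Compound 3 is therefore expected to show no step beyond the scatter in this assay, a 1.1-fold lower number from compound 1 to compound 3 (0.03 log units; within the scatter), with an estimated 40000 nM between 15000 nM and 110000 nM.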

Compound 3, half-maximal inhibitory concentration: 34300 nM
Compound 3: the middle estimate sits 1.2-fold (0.07 log units) above what was measured; measured number inside the range.
By their numbers in this assay, from the lowest: compounds 2, 3 and 1 (each within the scatter of the next).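

In this assay, hydrogen in place of 3,4,5-trihydroxy-6-(hydroxymethyl)oxan-2-yl on an oxygen on an aromatic ring gives a 1.3-fold lower number from compound 1 to compound 3 (0.10 log units; within the scatter). The whole group can therefore leave this oxygen without the number moving beyond the scatter, and the shared core without it stays in the same range as compound 1 and compound 2. Nothing available explains this result. The compounds shown leave open whether a methyl or an acetyl on this oxygen, or a carboxylic acid elsewhere on the core, would move the number beyond the scatter.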